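The source may report more compounds than this note shows. Statements on the series, on what has been measured and on what is new or still open speak of the compounds shown alone.

Values measured in a functional assay on cells (Neutrophil, Homo sapiens) for inhibition, with a stated time of 10 min (on this read-out higher numbers stand for weaker inhibition and lower numbers for stronger inhibition), follow.
- Compound 1 (`O=C(Nc1ccccc1)N1c2ccnn2CC1c1ccccc1`) gives > 1000 nM (a limit)
- Compound 2 (`CCOC(=O)c1cnn2c1N(C(=O)Nc1ccccc1)C(c1ccccc1)C2`) gives > 1000 nM (a limit)
- Compound 3 (`O=C(NC1CC1)c1cnn2c1N(C(=O)Nc1ccccc1)C(c1ccccc1)C2`) gives 13.2 nM

Going by the values given here, compound 3 at 13.2 nM holds the only exact number. The values of compound 1 and compound 2 are limits.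

Compound 4 (`O=C(c1cnn2c1N(C(=O)Nc1ccccc1)C(c1ccccc1)C2)N1CCCCC1`) is the next to read. It carries piperidin-1-yl in place of cyclopropylamino on a carbonyl carbon.

The nearest measured change sits at the same place. This is an at least 75-fold lower number from compound 2 to compound 3 (1.87 log units; beyond the scatter), with cyclopropylamino in place of ethoxy on a carbonyl carbon. The step of an at least 75-fold lower number from compound 1 to compound 3 (1.87 log units; beyond the scatter), with cyclopropylcarbamoyl in place of hydrogen on an aromatic carbon, is of the same size. Both sizes rest on (the limit of > 1000 nM in this assay, at which 2 of the 3 values shown sit), so each may be larger than it reads. The step that the two limits leave unreadable from compound 1 to compound 2 gives no size.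

The group on this carbonyl carbon has therefore made a large difference once already, and replacing cyclopropylamino is expected to give a clear rise in this assay, toward weaker inhibition. Among the compounds with values here, no measured compound carries piperidin-1-yl, so the size remains uncertain and a reading at the limit is possible.

The step expected is a 30-fold higher number from compound 3 to compound 4 (1.48 log units; beyond the scatter).

Compound 4 is estimated at 400 nM, with an expected range of 40 nM to 3000 nM.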

Compound 4, half-maximal inhibitory concentration: > 1000 nM
Compound 4 was reported as a limit (the forecaster's own chance of this, stated with the estimate: 45%); middle value at least 2.5-fold (0.39 log units) away from the limit.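

In this assay, the carbonyl carbon gives a second large change, an amide-to-amide one this time: an at least 75-fold higher number from compound 3 to compound 4 (1.87 log units; beyond the scatter). The low value of compound 3 therefore does not follow from simply having a ring-bearing nitrogen group on this carbonyl, since piperidin-1-yl, with its nitrogen in the ring, does not retain it, and the change also removes the hydrogen-bond donor counted on cyclopropylamino while enlarging the group. Compound 4 gives > 1000 nM, which is a limit, so this step may be larger than it reads and the steps among compound 1, compound 2 and compound 4 cannot be read: the limit of > 1000 nM in this assay, at which 3 of the 4 values shown sit.

The compounds shown do not separate the loss of the amide hydrogen from the change in group size and ring, as both differ together between cyclopropylamino and piperidin-1-yl. Cyclopentylamino, which keeps the amide hydrogen on a larger ring, and dimethylamino, which lacks that hydrogen and carries no ring, would pull these two differences apart, and how much room this position leaves around cyclopropylamino remains open.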